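A few compounds are considered here, and "the series" means these few. Any claim that something is new, unique, unknown or untested is made for them only; others in the source may bear on it.

Compound 1 `OC[C@@H](O)[C@@H](O)[C@H](O)c1c[nH]c(-c2cscn2)n1`: 4.2 h
Compound 2 `OC[C@@H](O)[C@@H](O)[C@H](O)c1c[nH]c(-c2ncc[nH]2)n1`: 3.2 h
Compound 3 `OC[C@@H](O)[C@@H](O)[C@H](O)c1c[nH]c(-c2ncccn2)n1`: 2.4 h

These three compounds share one core and differ only in the aromatic group on it. They were compared in an ADME assay on the whole organism (strain 129/SvEvBrd x C57BL/6) for metabolic stability, with Mus musculus as the target; a lower number here means that the compound disappears faster, a higher number that the compound lasts longer. There, compound 3 gives 2.4 h, the lowest of the three numbers, but it cannot be separated from the other two. The measured steps that reach it are a 1.3-fold lower number from compound 2 to compound 3 (0.12 log units; within the scatter) and a 1.8-fold lower number from compound 1 to compound 3 (0.24 log units; within the scatter), and both stay within the scatter. The remaining step, a 1.3-fold lower number from compound 1 to compound 2 (0.12 log units; within the scatter), is also within the scatter.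

Compound 4 `Cn1cnc(-c2nc([C@@H](O)[C@H](O)[C@H](O)CO)c[nH]2)c1` keeps the core and exchanges the aromatic group: 1-methyl-1H-imidazol-4-yl in place of pyrimidin-2-yl on an aromatic carbon. In words, 1-methyl-1H-imidazol-4-yl stands in place of pyrimidin-2-yl on an aromatic carbon. Within the data shown here, none of the measured compounds carries this group. The closest comparison by name is compound 2, with its 1H-imidazol-2-yl group, which gives 3.2 h. Among the measured compounds shown here, no measured step shows what the methyl group does.

Since each exchange of this group so far has stayed within the scatter, no step beyond the scatter is expected here. The estimated step is a 1.3-fold higher number from compound 3 to compound 4 (0.10 log units; within the scatter), and it is expected to lie within the scatter. For compound 4 the estimated half-life in this assay is 3 h, with an expected range from 1.6 h to 5.5 h.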

Compound 4, half-life: 1.6 h
Compound 4: middle estimate off by 1.9-fold (0.27 log units), on the high side; low and high end bracket the measured number.
By their numbers in this assay, from the lowest: compounds 4, 3, 2 and 1 (each within the scatter of the next, the first and the last beyond it).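

Among the exchanges of this group in this assay, the one leading to 1-methyl-1H-imidazol-4-yl gives the first step beyond the scatter, and a modest one: a 2.6-fold lower number from compound 1 to compound 4 (0.42 log units; beyond the scatter), whereas no earlier pair had separated. The same group stays within the scatter against the other two groups, with a 1.5-fold lower number from compound 3 to compound 4 (0.18 log units; within the scatter) and a 2.0-fold lower number from compound 2 to compound 4 (0.30 log units; within the scatter), so going from the six-membered aromatic ring of pyrimidin-2-yl to this five-membered aromatic ring does not separate those two compounds. This position, on an aromatic carbon between two ring nitrogen atoms, therefore shows a readable difference only between 1,3-thiazol-4-yl and 1-methyl-1H-imidazol-4-yl, and nothing available explains that difference.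

Among these compounds, what the methyl group itself contributes stays open: no pair here differs by that group alone, and 1H-imidazol-4-yl without the methyl would be the direct comparison for compound 4. Also open, on these data alone, is how this position would respond to a different kind of group in place of these aromatic rings, such as a phenyl ring, a primary amine or a carboxylic acid.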